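Pyridyl in place of hydroxyphenyl on the side chain

A few compounds are considered here, and "the series" means these few. Any claim that something is new, unique, unknown or untested is made for them only; others in the source may bear on it.

Compound 1 `CC(C)(C)C1=C(C(=O)O)N2C(=O)[C@H](CO)[C@H]2O1`: 5 h
Compound 2 `CC(C)(C)C1=C(C(=O)O)N2C(=O)[C@H]([C@H](O)c3ccccc3)[C@H]2O1`: 7 h
Compound 3 `CC(C)(C)C1=C(C(=O)O)N2C(=O)[C@H]([C@H](O)CCc3ccc(O)cc3)[C@H]2O1`: 24.6 h

In an ADME assay, in phosphate buffer, at 28 degrees C, at pH 7.0 (on this read-out higher numbers stand for a longer-lived compound and lower numbers for a shorter-lived compound), compound 3 holds the highest number of the three measured compounds, with 24.6 h, and its gap to each of the other two lies beyond the scatter. Compound 2 sits nearest, with 7 h, while compound 1 sits furthest, with 5 h. Compound 4 `CC(C)(C)C1=C(C(=O)O)N2C(=O)[C@H]([C@H](O)CCc3ccncc3)[C@H]2O1` differs from compound 3 in one place: pyridin-4-yl in place of 4-hydroxyphenyl on a saturated chain carbon, three bonds along the chain from an oxygen on a saturated carbon and a saturated ring carbon. Within the data shown here, only one measured step is available, a 1.4-fold higher number from compound 1 to compound 2 (0.15 log units; within the scatter), and it touches a different position and a different kind of exchange, so it offers no direct guide to the present change. Among the measured compounds shown here, no measured pair shows what replacing a 4-hydroxyphenyl by a pyridin-4-yl does on this read-out. Compound 4 is therefore expected, with wide uncertainty, to give a somewhat lower number than compound 3, estimated at 15 h with a range from 6 h to 40 h. The step this implies, a 1.6-fold lower number from compound 3 to compound 4 (0.21 log units; within the scatter), is an expectation that the measurement alone can settle.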

Compound 4, half-life: 13.7 h
Beside the measured number, compound 4's estimate is 1.1-fold (0.04 log units) above it, and the stated range covers the measured number.
By their numbers in this assay, from the lowest: compounds 1, 2, 4 and 3 (each within the scatter of the next, the first and the last beyond it).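

In this assay, pyridin-4-yl in place of 4-hydroxyphenyl at this place on the chain gives a 1.8-fold lower number from compound 3 to compound 4 (0.25 log units; within the scatter), so the hydrogen-bond donor of 4-hydroxyphenyl is not needed for the number to stay within the scatter of compound 3. The 2-(pyridin-4-yl)ethyl group gives a 2.7-fold higher number from compound 1 to compound 4 (0.44 log units; beyond the scatter), a modest step beyond the scatter, whereas its exchange for phenyl gives a 2.0-fold higher number from compound 2 to compound 4 (0.29 log units; within the scatter). No supporting measurement bears on what lies behind these steps.

The compounds shown leave open whether the ring at the end of this chain matters at all, since a plain phenyl or a pyridin-3-yl there would test that directly. They also leave open how a longer chain, or an amine or a carboxylic acid at its end, would read in this assay.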